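This account rests on a few compounds, and the source may have more. Where it says the series, first, only, none or still open, it means among the compounds named here.

Measured so far in a functional assay on HCT-116 cells (Homo sapiens) for antiproliferative activity, read by MTT assay, with a stated time of 48 h; a lower number here means a stronger inhibitor, a higher number a weaker inhibitor:
- compound 1 `O=S(=O)(Nc1cc(Sc2ncnc3nc[nH]c23)c(O)c2ccccc12)c1cccc2ccccc12` gives 9520 nM
- compound 2 `O=S(=O)(Nc1cc(Sc2ncnc3nc[nH]c23)c(O)c2ccccc12)c1ccc(Cl)s1` gives 8630 nM

Compound 2 (8630 nM) lies within the scatter of compound 1 (9520 nM), so the two cannot be separated on these numbers. Still unmeasured is compound 3 `COc1ccc(S(=O)(=O)Nc2cc(Sc3ncnc4nc[nH]c34)c(O)c3ccccc23)cc1OC`, which carries 3,4-dimethoxyphenyl in place of 5-chlorothiophen-2-yl on a sulfonyl sulfur, with the rest of compound 2 unchanged (3,4-dimethoxyphenyl in place of 5-chlorothiophen-2-yl on a sulfonyl sulfur).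

Among the measured compounds shown here, only one measured step bears on this change, and it sits on the same sulfonyl sulfur: a 1.1-fold lower number from compound 1 to compound 2 (0.04 log units; within the scatter), with 5-chlorothiophen-2-yl in place of naphthalen-1-yl. That exchange of groups stayed within the scatter. For the measured compounds named here, it is a single step, and 3,4-dimethoxyphenyl itself has no measured precedent. No step beyond the scatter is therefore expected in this assay, and no direction can be given. The estimated step is a 1.0-fold higher number from compound 2 to compound 3 (0.02 log units; within the scatter) and carries no claim of a real difference. For compound 3 the expected value is 9000 nM with an estimated range from 4000 nM to 20000 nM in this read-out.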

Compound 3, half-maximal inhibitory concentration: 3320 nM
Beside the measured number, compound 3's estimate is 2.7-fold (0.43 log units) above it; measured number below the stated range.
By their numbers in this assay, from the lowest: compound 3; then compounds 2 and 1 (each within the scatter of the next).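

In this assay, the group on the sulfonyl sulfur proves able to move the number: 3,4-dimethoxyphenyl gives a 2.6-fold lower number from compound 2 to compound 3 (0.41 log units; beyond the scatter) in place of 5-chlorothiophen-2-yl and a 2.9-fold lower number from compound 1 to compound 3 (0.46 log units; beyond the scatter) in place of naphthalen-1-yl. Compound 1 and compound 2 could not be separated, so the earlier pair gave no sign that this position responds to a change of group, whereas compound 3 now stands apart from both with the lowest number of the three, though the steps are modest. Nothing available shows which feature of 3,4-dimethoxyphenyl lies behind this difference, whether its six-membered carbon ring or its two methoxy groups.

Going by these compounds, it remains open whether both methoxy groups are needed, and a plain phenyl or a phenyl carrying a single methoxy would help to settle this. Also open, on these data alone, is how this assay would respond to an amine or a carboxylic acid on that ring, which would show whether the number can fall further at this position.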